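This account rests on a few compounds, and the source may have more. Where it says the series, first, only, none or still open, it means among the compounds named here.

Working notes on the series. Of the compounds shown here, three have been measured in a functional assay on SH-SY5Y cells (Homo sapiens) for cytotoxicity, read by MTT assay, with a stated time of 48 h; a lower number here means a stronger inhibitor, a higher number a weaker inhibitor. Compound 1, `N#CC(C#N)Cc1nccs1`, sits at a limit of the assay: in this assay compound 1 gives > 120000 nM. Compound 3, `O=S(=O)(CCC(F)=C(F)F)c1nc2ccc(OC(F)F)cc2[nH]1`, likewise sits at a limit of the assay: in this assay compound 3 gives > 120000 nM. Within the data shown here, compound 2, `[O-][S+](CCC(F)(Cl)C(F)(F)Cl)c1nc2ccccc2s1`, is the only member with a number: in this assay compound 2 gives 41500 nM. Among the measured compounds shown here, compound 2 thus stands alone as the single measured value, the other two entries being limits, as summarised by the limit of > 120000 nM in this assay, at which 2 of the 3 values shown sit. For the measured compounds named here, no pair of measured compounds differs in one place, so nothing measured sets the size of the change now under study.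

Compound 4, `[O-][S+](CCC(F)(Cl)C(F)(F)Cl)c1nc2ccc(Cl)cc2s1`, differs from compound 2 by chloro in place of hydrogen on an aromatic carbon. With no measured step of this kind in the series, the change is expected to stay within the usual scatter, with at most a slight shift toward a stronger inhibitor. Compound 4 is therefore estimated at 30000 nM in this assay, with a range from 10000 nM to 90000 nM. This corresponds to an expected step of a 1.4-fold lower number from compound 2 to compound 4 (0.14 log units; within the scatter).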

Compound 4, half-maximal inhibitory concentration: 2100 nM
Estimate against measurement, compound 4: 14-fold (1.15 log units) above; measured number below the stated range.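

In this assay, among these compounds, chloro in place of hydrogen on an aromatic carbon of the six-membered aromatic ring gives a 20-fold lower number from compound 2 to compound 4 (1.30 log units; beyond the scatter), the only measured step. This position, meta to a fused ring and para to a fused ring, is therefore sensitive to substitution in this read-out, with 1 heavy atom entering and a change well beyond the scatter. Nothing among the compounds shown accounts for the size of this step.

On these data alone, whether the step is particular to chloro remains open, since fluoro, a methoxy group or an amine at the same position would be needed to tell. Also open, as far as these compounds go, is whether the same change would give a step of similar size on a different side chain, such as a shorter alkyl chain.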